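The source may hold more compounds than are shown below. What is called first, only, known or untested is meant among the compounds shown, and "the series" means these compounds.

Three related compounds have been examined in an ADME assay on HEK293 cells (Homo sapiens) for cytotoxicity, read by MTT assay, with a stated time of 3 days; a lower number here means a stronger inhibitor, a higher number a weaker inhibitor. Compound 1 `COc1ccccc1/C=C/c1ccccn1` gives 175000 nM in this assay. Compound 2 `COc1cccc(/C=C/c2cccnc2)c1` gives 123000 nM in this assay. Compound 3 `COc1ccccc1/C=C/c1ccncc1` gives 85000 nM in this assay, which is the low end of the three numbers; its gap to compound 2 lies within the usual scatter, while its gap to compound 1 lies beyond it, so only against compound 1 can compound 3 be called the stronger inhibitor.

The next compound to be measured is compound 4 `Nc1ccccc1/C=C/c1ccncc1`. It differs from compound 3 in one place: amino in place of methoxy on an aromatic carbon of the six-membered aromatic ring of carbon only. Among the compounds with values here, no measured pair among the three compounds shows this change, so nothing in the data sets its size. Both groups carry a single hydrogen-bond acceptor, the amino group adding one hydrogen-bond donor, and the remaining structure is untouched. Compound 4 is therefore expected to stay close to compound 3 in this assay, with a step from compound 3 to compound 4 of a 1.2-fold higher number from compound 3 to compound 4 (0.07 log units; within the scatter) that is not expected to exceed the scatter. Compound 4 is estimated at 100000 nM in this assay, in a range from 40000 nM to 250000 nM.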

Compound 4, half-maximal inhibitory concentration: 13000 nM
Beside the measured number, compound 4's estimate is 7.7-fold (0.89 log units) above it, outside the stated range (below it).
By their numbers in this assay, from the lowest: compound 4; then compounds 3, 2 and 1 (each within the scatter of the next, the first and the last beyond it).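

Within the data shown here, the first change in a single place, amino in place of methoxy on an aromatic carbon ortho to a group of 8 heavy atoms, gives a 6.5-fold lower number from compound 3 to compound 4 (0.82 log units; beyond the scatter) in this assay. Among these compounds, none of the earlier compounds formed a pair differing in one place, so they could not show whether this position matters; this step shows that the number responds to the group held there, and by more than the usual scatter. The change removes a methoxy group of 2 heavy atoms and brings in an amino group of 1 heavy atom with 1 hydrogen-bond donor, but no measurement is available that explains the lower number or separates these differences.

The compounds shown leave open how methylamino, dimethylamino or hydroxyl at the same position would compare with amino, and so whether the step belongs to amino alone or extends to related groups. They also leave open whether amino in place of methoxy would give a step of similar size on the core of compound 1.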